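A few compounds are considered here, and "the series" means these few. Any claim that something is new, unique, unknown or untested is made for them only; others in the source may bear on it.

Measured so far in a functional assay on CHO cells with adenosine receptor A1 (Homo sapiens) as the target, read by cAMP accumulation and immunoassay, with a stated time of 6 min, tested at 1 uM; on this read-out lower numbers stand for a stronger effect and higher numbers for a weaker effect at the one concentration tested:
compound 1, `Nc1scc(CN2CCN(c3ccccc3C(F)(F)F)CC2)c1C(=O)c1ccc(Cl)cc1`: -39%
compound 2, `Nc1scc(CN2CCN(c3cccc(F)c3)CC2)c1C(=O)c1cccc(C(F)(F)F)c1`: -35%

In this assay compound 1 gives -39% and compound 2 gives -35%. Compound 1 has the lower of the two numbers, but compound 2 stands only a few points higher, so the two values lie within the scatter of each other and no order between them can be claimed. Compound 1 and compound 2 differ in more than one place, so no single step can be read from that pair.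

Compound 3, `Nc1scc(CN2CCN(c3ccc(F)cc3F)CC2)c1C(=O)c1ccc(Cl)cc1`, has not yet been measured. It differs from compound 1 in one place: 2,4-difluorophenyl in place of 2-(trifluoromethyl)phenyl on an amine nitrogen in a ring. The rest of the structure, including the six-membered non-aromatic ring with 2 nitrogen and the ketone-bearing core, is kept.

Going by the values given here, no step between measured compounds exists in this set, so there is nothing that tells how a change on an amine nitrogen in a ring moves the read-out of this assay. The expectation for the step from compound 1 to compound 3 is therefore a small one, a number 4 percentage points higher from compound 1 to compound 3 (within the scatter), not beyond the scatter. Compound 3 is expected to give about -35% in this assay, estimated between -58% and -12%.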

Compound 3, a percentage reported as activity, at one concentration (the size of the read-out at that concentration, not a potency): -66%
Compound 3: middle estimate off by 31 percentage points, on the high side; measured number outside the range, below it.
By their numbers in this assay, from the lowest: compound 3; then compounds 1 and 2 (each within the scatter of the next).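

In this assay, going by these compounds alone, 2,4-difluorophenyl in place of 2-(trifluoromethyl)phenyl on an amine nitrogen in a ring gives a number 27 percentage points lower from compound 1 to compound 3 (beyond the scatter) and is the only single-place step available. The aryl group on this nitrogen is therefore not a silent position for this read-out: with the six-membered non-aromatic ring with 2 nitrogen and the rest of the structure kept, exchanging this one group moves the number by more than repeat measurements would. No measurement shown here bears on why the read-out moves with this exchange.

The step removes trifluoromethyl and adds two fluorines in one change, so it cannot assign the shift to either part, and an unsubstituted phenyl or a 2-fluorophenyl on the same nitrogen would be needed to separate them. As far as these compounds go, it also remains open whether the same exchange carries over to the different aryl ketone of compound 2, and whether a read-out taken at one concentration reflects any difference in potency.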